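Carbonyl substituent series: cyclohexyl in place of benzylamino

The source may hold more compounds than are shown below. What is called first, only, known or untested is meant among the compounds shown, and "the series" means these compounds.

Measured so far:
compound 1 `CC(C)CCN(C)Cc1cn(CC(O)COC(=O)c2ccccc2)nn1` — in an assay on nucleic acid for inhibition of Nucleic Acid, read by fluorescence, tested at 100 uM (a lower number here means less inhibition, a higher number more inhibition at the concentration tested (going by the name of the read-out)), compound 1 gives 0%
compound 2 `CC(C)CCN(C)Cc1cn(CC(O)COC(=O)NCc2ccccc2)nn1` — in this assay compound 2 gives 26%

For the measured compounds named here, compound 2 holds the higher of the two numbers; the only measured step is a number 26 percentage points higher from compound 1 to compound 2 (beyond the scatter), a modest gain.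

Compound 3 `CC(C)CCN(C)Cc1cn(CC(O)COC(=O)C2CCCCC2)nn1` is not yet measured. It differs from compound 2 as follows:

cyclohexyl in place of benzylamino on a carbonyl carbon

Going by the values given here, the one step that bears on this change is a number 26 percentage points higher from compound 1 to compound 2 (beyond the scatter), which came with benzylamino entering on the carbonyl carbon. Compound 3 takes benzylamino away again and places a six-membered ring directly on that carbon, as compound 1 has a six-membered ring there. The number is therefore expected to fall back toward the level of compound 1 because a number 26 percentage points higher from compound 1 to compound 2 (beyond the scatter) was the whole of the gain seen. A downward step is estimated: a number 18 percentage points lower from compound 2 to compound 3 (beyond the scatter). Compound 3 is expected to give 8%, within a range from 0% to 25%.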

Compound 3, a percentage reported as inhibition, at one concentration (the size of the read-out at that concentration, not a potency): 0%
The estimate for compound 3 lay 8 percentage points above the measured number; the measured number falls inside the stated range.
By their numbers in this assay, from the lowest: compounds 1 and 3 (each within the scatter of the next); then compound 2.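

In this assay, cyclohexyl in place of benzylamino on a carbonyl carbon gives a number 26 percentage points lower from compound 2 to compound 3 (beyond the scatter), whereas cyclohexyl in place of phenyl gives no change at the digits printed from compound 1 to compound 3 (within the scatter). At this position, exchanging the aromatic ring of compound 1 for the non-aromatic ring of compound 3 therefore moves the number by no more than the scatter, and of the three compounds only compound 2, with benzylamino, stands apart from the other two. Nothing available explains why benzylamino differs from the two directly attached rings.

Still open, on these data alone, is whether the number of compound 2 goes with the nitrogen of benzylamino, with its aromatic ring or with both together. Benzyl and cyclohexylamino on the same carbonyl carbon would separate these two parts.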